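Swapping the benzyl group on compound 2

The source may hold more compounds than are shown below. What is called first, only, known or untested is meant among the compounds shown, and "the series" means these compounds.

In a physicochemical assay for lipophilicity, at pH 7.4 (a lower number here means a more polar compound, a higher number a more lipophilic compound), compound 1 `Cc1cc(N[C@H](CCCCN)C(=O)NO)cc(C)c1F` gives < 3 as a limit of the assay and not a number. Compound 2 `Cc1cc(CNCCCC[C@@H](Nc2cc(C)c(F)c(C)c2)C(=O)NO)ccc1F` gives < 3 as a limit too. Compound 3 `Cc1cc(NC(=O)NCCCC[C@@H](Nc2cc(C)c(F)c(C)c2)C(=O)NO)ccc1F` gives < 3 as a limit as well. Compound 2 therefore has no exact place on the scale, and the limit of < 3 in this assay, at which 3 of the 3 values shown sit, is all that the results show so far.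

Compound 4 `COc1ccc(CNCCCC[C@@H](Nc2cc(C)c(F)c(C)c2)C(=O)NO)cc1` has not yet been measured. It carries 4-methoxyphenyl in place of 4-fluoro-3-methylphenyl on a saturated chain carbon bound to an amine nitrogen, a difference that also reads as 4-fluoro-3-methylbenzyl to 4-methoxybenzyl.

Among the compounds with values here, the only measured step that bears on this part of the molecule is a step that the two limits leave unreadable from compound 1 to compound 2 and it gives no size to carry over, so no change beyond the usual scatter is expected. The estimated step that the limit leaves unreadable from compound 2 to compound 4 is expected to stay within that scatter in this assay with no direction that the data can support. For compound 4 the estimated value is 2.3 with an expected range of 1.5 to 3 and the assay may well report only a limit again.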

Compound 4, distribution coefficient: < 3
Compound 4 was reported as a limit (the forecaster's own chance of this, stated with the estimate: 85%); the middle value is on the limit's open side.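

In this assay compound 4 gives < 3, a limit of the assay and not a number. No step can be read from compound 2 to compound 4, or from compound 1 to either of them. All the results share one position: the limit of < 3 in this assay, at which 4 of the 4 values shown sit. Where any of the four compounds sits on the scale, and whether 4-methoxybenzyl and 4-fluoro-3-methylbenzyl differ at all, stays open.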